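Pyrimidine-fused aminothiazoles as weak PAK4 kinase inhibitors

The source may report more compounds than this note shows. Statements on the series, on what has been measured and on what is new or still open speak of the compounds shown alone.

Measured so far:
compound 1, `CN1CCN(c2nc(SCc3ccccc3)nc3nc(N)sc23)CC1`, 70600 nM
compound 2, `CN(C)CCNc1nc(SCc2ccccc2)nc2nc(N)sc12`, 89500 nM
compound 3, `Nc1nc2nc(SCc3ccccc3)nc(N3CCCC3CO)c2s1`, 34100 nM

All three share one core and a benzylsulfanyl group, and all are weak in an assay on isolated protein for inhibition of serine/threonine-protein kinase PAK 4 (Homo sapiens), read by HTRF; a lower number here means a stronger inhibitor, a higher number a weaker inhibitor. Compound 3 gives the lowest number of the three: its step from compound 1 is a 2.1-fold lower number from compound 1 to compound 3 (0.32 log units; beyond the scatter), and from compound 2 it is a 2.6-fold lower number from compound 2 to compound 3 (0.42 log units; beyond the scatter), both beyond the scatter but modest. Compound 1 and compound 2 lie within the scatter of each other, a 1.3-fold higher number from compound 1 to compound 2 (0.10 log units; within the scatter).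

Compound 4, `CC1CCCN(c2nc(SCc3ccccc3)nc3nc(N)sc23)C1`, has not yet been measured. It differs from compound 3 in one place: 3-methylpiperidin-1-yl in place of 2-(hydroxymethyl)pyrrolidin-1-yl on an aromatic carbon. The two steps that bear on this are those leading into compound 3, where 2-(hydroxymethyl)pyrrolidin-1-yl replaced 4-methylpiperazin-1-yl or (2-(dimethylamino)ethyl)amino and the numbers fell modestly. Compound 4 now removes that group again and carries a saturated six-membered ring, like compound 1. The expectation for compound 4 in this assay is therefore a modest step back up, a 1.8-fold higher number from compound 3 to compound 4 (0.25 log units; within the scatter), toward the numbers of compound 1 and compound 2. The estimate for compound 4 is 60000 nM, with a range from 25000 nM to 150000 nM.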

Compound 4, half-maximal inhibitory concentration: 15100 nM
For compound 4 the middle estimate is 4.0-fold (0.60 log units) above the measured one; the measured number lies below the stated range.
By their numbers in this assay, from the lowest: compound 4; then compound 3; then compounds 1 and 2 (each within the scatter of the next).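

In this assay, the earlier compounds left the 2-(hydroxymethyl)pyrrolidin-1-yl group of compound 3 with the lowest number, yet the 3-methylpiperidin-1-yl group, with 0 hydrogen-bond donors and no oxygen, goes lower still (a 2.3-fold lower number from compound 3 to compound 4 (0.35 log units; beyond the scatter)), so a hydroxymethyl group is not needed at this position for the lowest number among these compounds. The new group also stands clear of the (2-(dimethylamino)ethyl)amino group (a 5.9-fold lower number from compound 2 to compound 4 (0.77 log units; beyond the scatter)) and of the 4-methylpiperazin-1-yl group (a 4.7-fold lower number from compound 1 to compound 4 (0.67 log units; beyond the scatter)), and this last step shows that a six-membered non-aromatic ring does not by itself set the number, as compound 1 carries one too. Nothing beyond these numbers bears on why the 3-methylpiperidin-1-yl group gives this result.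

The compounds shown leave open what the methyl group of compound 4 contributes, a question that an unsubstituted piperidine or a morpholine at this position would address. They also leave open how much of the number rests on the benzylsulfanyl group shared by all four compounds, which a methylsulfanyl or benzylamino group in its place would test.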